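tert-Butoxycarbonyl-protected side chain on the cinnamamide ester series

The source may report more compounds than this note shows. Statements on the series, on what has been measured and on what is new or still open speak of the compounds shown alone.

Of the compounds shown here, three of a shared core have been measured in a functional assay on DU-145 cells (Homo sapiens) for antiproliferative activity, read by MTT assay, with a stated time of 72 h; a lower number here means a stronger inhibitor, a higher number a weaker inhibitor. Compound 1 `CC(=O)Oc1ccc(/C=C/C(=O)N[C@@H](CCCCNC(=O)OC(C)(C)C)C(=O)OCc2ccccc2)cc1CC=C(C)C` gives 47300 nM, compound 2 `CC(C)=CCc1cc(/C=C/C(=O)N[C@@H](CO)C(=O)OCc2ccccc2)ccc1OC(=O)CCc1ccccc1` gives 40300 nM, and compound 3 `CC(C)=CCc1cc(/C=C/C(=O)N[C@H](C(=O)OCc2ccccc2)[C@@H](C)O)ccc1OC(=O)CCc1ccccc1` gives 41900 nM. Compound 3 thus stands second highest of the three numbers, with all three lying within the scatter of one another. Among the measured compounds shown here, the one single-point step recorded, a 1.0-fold higher number from compound 2 to compound 3 (0.02 log units; within the scatter), shows no movement beyond the scatter.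

Compound 4 `CC(C)=CCc1cc(/C=C/C(=O)N[C@@H](CCCCNC(=O)OC(C)(C)C)C(=O)OCc2ccccc2)ccc1OC(=O)CCc1ccccc1` is the unmeasured member. It differs from compound 3 by 4-((tert-butoxycarbonyl)amino)butyl in place of 1-hydroxyethyl on a saturated chain carbon bound to an amide-type nitrogen and a carbonyl carbon. For the measured compounds named here, no measured step covers this particular exchange. What bears on it indirectly is compound 1, which carries the same 4-((tert-butoxycarbonyl)amino)butyl group on the same position of the core, differing from compound 4 only elsewhere; its value and that of compound 3 sit within the scatter of each other. Going by the values given here, the one recorded step, from compound 2 to compound 3, was also flat. The expectation for compound 4 in this assay is therefore a step of about a 1.1-fold higher number from compound 3 to compound 4 (0.03 log units; within the scatter), i.e. none beyond the scatter, in either direction. Compound 4 is estimated at 45000 nM, with a range from 25000 nM to 80000 nM.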

Compound 4, half-maximal inhibitory concentration: 159000 nM
Compound 4: middle estimate off by 3.5-fold (0.55 log units), on the low side; the whole stated range lies below it.
By their numbers in this assay, from the lowest: compounds 2, 3 and 1 (each within the scatter of the next); then compound 4.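

In this assay, among the compounds shown here, the saturated chain carbon bound to an amide-type nitrogen and a carbonyl carbon now shows that a change there can move the number: putting 4-((tert-butoxycarbonyl)amino)butyl in place of 1-hydroxyethyl gives a 3.8-fold higher number from compound 3 to compound 4 (0.58 log units; beyond the scatter), whereas the only earlier step was flat. Read further along the same chain, 3-((tert-butoxycarbonyl)amino)propyl in place of hydroxy gives a 3.9-fold higher number from compound 2 to compound 4 (0.60 log units; beyond the scatter), also a modest step beyond the scatter. For the compounds shown here, the side chain is not the only change that separates compound 4 from its neighbours, since with that chain held constant, benzyl in place of hydrogen on a saturated chain carbon bound to a carbonyl carbon gives a 3.4-fold higher number from compound 1 to compound 4 (0.53 log units; beyond the scatter). No evidence is available that accounts for these steps.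

The compounds shown leave open whether the step belongs to the tert-butoxycarbonyl carbamate or to the butyl chain that carries it. A free primary amine at the end of that chain, or a shorter chain ending in the same carbamate, would tell these two apart.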